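The source may hold more compounds than are shown below. What is called first, only, known or untested is meant among the compounds shown, and "the series" means these compounds.

Working notes, a functional assay on MCF7 cells (Homo sapiens) for antiproliferative activity, read by CellTiter-Glo, with a stated time of 5 days; a lower number here means a stronger inhibitor, a higher number a weaker inhibitor: compound 1 `CC/C(=C(/c1ccc(/C=C/C(=O)O)cc1)c1ccc2ncsc2c1)c1ccccc1` is recorded only as a limit, > 500 nM. For the measured compounds named here, compound 2 `CC/C(=C(/c1ccc(/C=C/C(=O)O)cc1)c1ccc2scnc2c1)c1ccccc1` gives 90 nM, the only exact number so far. Next is compound 3 `CC/C(=C(/c1ccc(/C=C/C(=O)O)cc1)c1ccc2ccccc2c1)c1ccccc1`, with naphthalen-2-yl in place of 1,3-benzothiazol-5-yl on a double-bonded chain carbon bound to an aromatic carbon and a double-bonded chain carbon. Going by the values given here, the one measured step at this place is an at least 5.5-fold lower number from compound 1 to compound 2 (0.74 log units; beyond the scatter), a change between the two benzothiazolyl attachments that lies beyond the scatter. It shows that this place can respond strongly, but it does not test a naphthalen-2-yl group. The expected step, a 1.2-fold higher number from compound 2 to compound 3 (0.09 log units; within the scatter), is therefore none beyond the scatter, with real uncertainty toward a higher number. For compound 3 the estimated value is 110 nM, with an expected range of 35 nM to 400 nM.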

Compound 3, half-maximal inhibitory concentration: 180 nM
Estimate against measurement, compound 3: 1.6-fold (0.21 log units) below; the measured number falls inside the stated range.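

In this assay, naphthalen-2-yl in place of 1,3-benzothiazol-5-yl gives a 2.0-fold higher number from compound 2 to compound 3 (0.30 log units; within the scatter), so the ring nitrogen and sulfur of 1,3-benzothiazol-5-yl are not required at this place for a number of this size. Naphthalen-2-yl in place of 1,3-benzothiazol-6-yl gives an at least 2.7-fold lower number from compound 1 to compound 3 (0.44 log units; beyond the scatter). That step is only a bound, since the value of compound 1 is a limit: the limit of > 500 nM in this assay, at which 1 of the 3 values shown sits.

Still open, on these data alone, is whether a hydroxyl or an amine on the naphthalen-2-yl group would shift the number, and how a single phenyl ring would compare at this place.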